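Returning a fused two-ring amide substituent on a p300 inhibitor

This account rests on a few compounds, and the source may have more. Where it says the series, first, only, none or still open, it means among the compounds named here.

Measured compounds:
compound 1 `O=C(Nc1ccc2[nH]ccc2n1)[C@H]1CCCN1C(=O)C1(c2cccc(Cl)c2)CCCC1`: 0.159 nM
compound 2 `COc1ccc(NC(=O)[C@H]2CCCN2C(=O)C2(c3cccc(Cl)c3)CCCC2)cc1`: 100 nM

Compound 2 stands highest of the two numbers in an assay on isolated protein for inhibition of histone acetyltransferase p300 (Homo sapiens), with a stated time of 60 min; a higher number here means a weaker inhibitor, a lower number a stronger inhibitor; its nearest neighbour is compound 1, which gives 0.159 nM. For the measured compounds named here, the single step of a 630-fold higher number from compound 1 to compound 2 (2.80 log units; beyond the scatter) shows that swapping the fused two-ring group for 4-methoxyphenyl on the amide-type nitrogen sharply weakened inhibition. Compound 3 `O=C(Nc1ccc2[nH]ncc2c1)[C@H]1CCCN1C(=O)C1(c2cccc(Cl)c2)CCCC1` reverses that kind of change: 1H-indazol-5-yl in place of 4-methoxyphenyl on an amide-type nitrogen. Since the fused group returns, though with a different ring type, a large drop in the number is expected, a 50-fold lower number from compound 2 to compound 3 (1.70 log units; beyond the scatter), probably not fully back to compound 1. Compound 3 is estimated at 2 nM, between 0.3 nM and 15 nM.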

Compound 3, half-maximal inhibitory concentration: 1 nM
For compound 3 the middle estimate is 2.0-fold (0.30 log units) above the measured one, and the stated range covers the measured number.
By their numbers in this assay, from the lowest: compound 1; then compound 3; then compound 2.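

For the compounds shown here, the fused group does not have to be the one in compound 1: 1H-indazol-5-yl on the amide-type nitrogen recovers most of the lost inhibition (a 100-fold lower number from compound 2 to compound 3 (2.00 log units; beyond the scatter)). The two fused groups are still not interchangeable (a 6.3-fold higher number from compound 1 to compound 3 (0.80 log units; beyond the scatter)), so at this position the identity of the fused rings counts, not only their presence. Nothing measured here explains either step.

On these data alone, it remains open whether the fused shape or the ring nitrogens account for the change. As far as these compounds go, it is also open how a phenyl ring carrying an amine instead of methoxy would compare.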